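Azido to Amino on the Sugar: An Antiproliferative Comparison

The source may hold more compounds than are shown below. What is called first, only, known or untested is meant among the compounds shown, and "the series" means these compounds.

Compound 1 `Cc1cn([C@@H]2O[C@H](CO)[C@@H](CF)[C@H]2O)c(=O)[nH]c1=O` gives > 100 uM in a functional assay on P388 cells (Mus musculus) for antiproliferative activity, with a stated time of 72 h (on this read-out higher numbers stand for an effect only at larger amounts of compound and lower numbers for an effect already at smaller amounts), which is a limit of the assay and not a number.
Compound 2 `Cc1cn([C@@H]2O[C@H](CO)[C@@H](CN)[C@@H]2O)c(=O)[nH]c1=O` gives > 100 uM in this assay, again only a limit.
Compound 3 `Cc1cn([C@@H]2O[C@H](CO)[C@@H](CN=[N+]=[N-])[C@H]2O)c(=O)[nH]c1=O` gives > 100 uM in this assay, also only a limit.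

Compound 3 therefore stands at the assay limit, where every value shown sits (the limit of > 100 uM in this assay, at which 3 of the 3 values shown sit). The change to compound 4 `Cc1cn([C@@H]2O[C@H](CO)[C@@H](CN)[C@H]2O)c(=O)[nH]c1=O` is amino in place of azido on a saturated chain carbon bound to a saturated ring carbon. Within the data shown here, the only measured step touching compound 3, a step that the two limits leave unreadable from compound 1 to compound 3, has limits at both ends and so gives no size. Compound 2, which also carries an aminomethyl group, likewise reached only the limit. No readable step exists to build on, so the expectation is no change beyond the limit: a step that the limit leaves unreadable from compound 3 to compound 4. Compound 4 is estimated at 150 uM, between 50 uM and 500 uM, most likely reported again only as a limit.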

Compound 4, concentration for half-maximal effect: > 100 uM
Compound 4 was reported as a limit; the forecaster's own chance of this, stated with the estimate: 85%; the middle value does not contradict the limit.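

Compound 4, like compounds 1, 2 and 3, reached only a limit, so no step among these compounds can be read: the limit of > 100 uM in this assay, at which 4 of the 4 values shown sit. The compounds shown leave open whether swapping azido for amino, or the configuration separating compound 2 from compound 4, changes anything in this assay.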